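The source may report more compounds than this note shows. Statements on the series, on what has been measured and on what is new or still open speak of the compounds shown alone.

Measured in a functional assay on Jurkat cells (Homo sapiens) for inhibition, read by MTT assay, with a stated time of 72 h; a higher number here means a weaker inhibitor of growth, a lower number a stronger inhibitor of growth:

compound 1 `Nc1cc(-c2ccc(Cl)cc2)nn1-c1cccc(Cl)c1` gives > 100000 nM
compound 2 `Cc1ccc(-c2nn(-c3cccc(Cl)c3)c(/N=C/N(C)C)c2C=O)cc1` gives 7800 nM
compound 3 `CN(C)/C=N/c1cc(-c2ccc(Cl)cc2)nn1-c1cccc(Cl)c1` gives 74500 nM

The value of compound 1 is a limit of the assay rather than a number, as recorded in the limit of > 100000 nM in this assay, at which 1 of the 3 values shown sits. Compound 3 gives a higher number than compound 2, and that gap lies beyond the usual scatter. Compounds 3 and 1 differ in one place, (one nitrogen atom in place of a group of 5 heavy atoms (3 carbon, 2 nitrogen; no ring), on an aromatic carbon), and this change produced an at least 1.3-fold higher number from compound 3 to compound 1 (0.12 log units; that floor lies within the scatter). That step is only a floor. The value of compound 1 is a limit.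

Compound 4 `Cc1ccc(-c2nn(-c3cccc(Cl)c3)c(N)c2C=O)cc1` has not yet been measured. It differs from compound 2 in a single place, (one nitrogen atom in place of a group of 5 heavy atoms (3 carbon, 2 nitrogen; no ring), on an aromatic carbon). The surroundings are not word for word the same as in the measured pair: in compound 2 the changed carbon is also next to the ring atom that bears a formyl group, and the group two ring bonds away is 4-methylphenyl rather than 4-chlorophenyl, so this is the same kind of change, not the same change. How the cores of compound 2 and compound 3 differ is not broken down here.

Going by the values given here, the one measured example of this kind of change points, weakly, toward a higher number. The expected step is a 2.6-fold higher number from compound 2 to compound 4 (0.41 log units; beyond the scatter), resting on an at least 1.3-fold higher number from compound 3 to compound 1 (0.12 log units; that floor lies within the scatter). Compound 4 is therefore expected to give about 20000 nM. The estimated range for compound 4 runs from 6000 nM to 80000 nM.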

Compound 4, concentration for 50% growth inhibition: 86300 nM
Estimate against measurement, compound 4: 4.3-fold (0.63 log units) below; the whole stated range lies below it.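

On the core of compound 2, putting amino in place of the group of 5 heavy atoms gives an 11-fold higher number from compound 2 to compound 4 (1.04 log units; beyond the scatter) in this assay, so compound 4 is a much weaker inhibitor of growth than compound 2. Setting this beside the earlier pair shows how far the change can be compared across the two cores: the same change on two cores in this assay, an at least 1.3-fold higher number (0.12 log units; that floor lies within the scatter) from compound 3 to compound 1 and an 11-fold higher number (1.04 log units; beyond the scatter) from compound 2 to compound 4; the limit leaves it open whether they differ The value of compound 1 is a limit of the assay and not a number, so the step on that core is known only as a floor, and these two pairs show neither that the large step on the core of compound 2 carries over to the other core nor that it fails to.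

The compounds shown hold only amino and the group of 5 heavy atoms at this place, which leaves open how a methylamino or an acetamido group there would read in this assay. They also leave open what the formyl group contributes, and whether 4-methylphenyl and 4-chlorophenyl matter to the size of the step, as no pair shown differs in only one of these groups.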